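Diaryl urea series: chloro in place of trifluoromethyl

This account rests on a few compounds, and the source may have more. Where it says the series, first, only, none or still open, it means among the compounds named here.

Compound 1 `COc1cc2cc(Oc3ccc(NC(=O)Nc4ccc(C(F)(F)F)cc4)cc3)c(C)nc2cc1OC` gives 76.7% in a functional assay on SK-MEL-2 cells (Homo sapiens) for inhibition, read by sulforhodamine B assay, with a stated time of 48 h, tested at 10 uM; a higher number here means a weaker effect of the compound at the concentration tested, a lower number a stronger effect. Compound 2 `COc1cc2cc(Oc3ccc(NC(=O)Nc4ccc(Cl)c(C(F)(F)F)c4)cc3)c(C)nc2cc1OC` gives -49.8% in this assay, the lowest of the two numbers shown, and the only measured step, a number 126.5 percentage points lower from compound 1 to compound 2 (beyond the scatter), is large. Compound 3 `COc1cc2cc(Oc3ccc(NC(=O)Nc4ccc(Cl)c(Cl)c4)cc3)c(C)nc2cc1OC` differs from compound 2 by chloro in place of trifluoromethyl on an aromatic carbon. Among the compounds with values here, no measured step matches this change; the step from compound 1 to compound 2 only shows that substitution on this ring can move the read-out strongly. A step of a number 19.8 percentage points higher from compound 2 to compound 3 (beyond the scatter) is expected, modest against that change and possibly within the scatter. Compound 3 is estimated at -30%, between -70% and 20%.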

Compound 3, a percentage reported as activity, at one concentration (the size of the read-out at that concentration, not a potency): -7.82%
The estimate for compound 3 lay 22.2 percentage points below the measured number, within the range that was stated.
By their numbers in this assay, from the lowest: compound 2; then compound 3; then compound 1.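

In this assay, chloro in place of trifluoromethyl on an aromatic carbon, ortho to a chloro group, gives a number 42 percentage points higher from compound 2 to compound 3 (beyond the scatter), so the read-out depends on which of these two groups sits at this place. The 3,4-dichlorophenyl urea still gives a number 84.5 percentage points lower from compound 1 to compound 3 (beyond the scatter), so the trifluoromethyl group is not needed here for a read-out lower than that of compound 1. No evidence bears on the reason for either step.

Open, on these data alone, is how a methoxy group, an amine or a nitrile at this place would read. Also open, as far as these compounds go, is whether the same change carries over to other substitution on this ring.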